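Amide heteroaryl exchange in the thiazolidinedione series

A few compounds are considered here, and "the series" means these few. Any claim that something is new, unique, unknown or untested is made for them only; others in the source may bear on it.

Measured so far:
compound 1 `O=C(COc1ccc2cc(/C=C3/SC(=O)NC3=O)ccc2c1)Nc1ccccn1` gives 17000 nM
compound 2 `O=C(COc1ccc2cc(/C=C3/SC(=O)NC3=O)ccc2c1)Nc1cccc(F)n1` gives 840 nM

Both numbers come from an assay on isolated protein for inhibition of histone deacetylase 4 (Homo sapiens), with a stated time of 1 h; a higher number here means a weaker inhibitor, a lower number a stronger inhibitor. Compound 2 stands lowest of the two; its nearest neighbour is compound 1, and the step of a 20-fold lower number from compound 1 to compound 2 (1.31 log units; beyond the scatter) is the only one on record. That step is fluoro in place of hydrogen on an aromatic carbon, and it is large.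

Compound 3 `Cc1cc(NC(=O)COc2ccc3cc(/C=C4/SC(=O)NC4=O)ccc3c2)no1` is not yet measured. It differs from compound 2 by 5-methyl-1,2-oxazol-3-yl in place of 6-fluoropyridin-2-yl on an amide-type nitrogen. Among the measured compounds shown here, no measured pair exchanges one ring for another on the amide-type nitrogen, so the measured step bears on this change only indirectly: the 6-fluoropyridin-2-yl group that now leaves is the group that carried the gain from compound 1 to compound 2, and that gain is given up along with it. A step toward a higher number, beyond the scatter but short of the full distance back to compound 1, is therefore the working expectation: a 4.2-fold higher number from compound 2 to compound 3 (0.62 log units; beyond the scatter). Compound 3 is estimated at 3500 nM, within 600 nM to 20000 nM, with wide uncertainty in both directions.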

Compound 3, half-maximal inhibitory concentration: 1700 nM
For compound 3 the middle estimate is 2.1-fold (0.31 log units) above the measured one; measured number inside the range.
By their numbers in this assay, from the lowest: compound 2; then compound 3; then compound 1.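

In this assay, the amide-type nitrogen tolerates replacement of the whole ring as well as substitution on the pyridine: 5-methyl-1,2-oxazol-3-yl in place of pyridin-2-yl gives a 10-fold lower number from compound 1 to compound 3 (1.00 log units; beyond the scatter). A lower number at this position is therefore not tied to the 6-fluoropyridin-2-yl group or to a six-membered ring, although 5-methyl-1,2-oxazol-3-yl in place of 6-fluoropyridin-2-yl gives a 2.0-fold higher number from compound 2 to compound 3 (0.31 log units; beyond the scatter), leaving compound 2 with the lowest number of the three. No measurement is available to explain either step.

The compounds shown do not separate the contribution of the methyl group from that of the five-membered ring, a question that the unsubstituted 1,2-oxazol-3-yl group would address directly. They also leave open whether the fluoro group is a particular requirement on the pyridine or whether other groups in that place, such as chloro in 6-chloropyridin-2-yl or methyl in 6-methylpyridin-2-yl, would give a similar step from compound 1.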